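The compounds below may be only part of what the source reports. "The series", "measured", "known", "first", "only" and "open" are said of these compounds alone.

Measured in a functional assay on HeLa cells (Homo sapiens) for inhibition, with a stated time of 72 h; a higher number here means that more compound is needed for the effect, a lower number that less compound is needed:
- compound 1 `COc1cc(CNC2CCCCC2)ccc1OCc1ccc(Cl)nc1`: "nd(insoluble)" (no result reported)
- compound 2 `COc1cc(CNCc2ccc(C(=O)O)cc2)ccc1OCc1ccc(Cl)nc1`: "nd(insoluble)" (no result reported)
- compound 3 `COCCNCc1ccc(OCc2ccc(Cl)nc2)c(OC)c1`: 97000 nM

Only compound 3 has a number, so it cannot yet be ranked against anything. Compound 4 `COc1cc(CNCc2cccs2)ccc1OCc1ccc(Cl)nc1` keeps the shared core and brings one structural change: thiophen-2-yl in place of methoxymethyl on a saturated chain carbon bound to an amine nitrogen. In words, this is thiophen-2-yl in place of methoxymethyl on a saturated chain carbon bound to an amine nitrogen. Among the compounds with values here, no measured pair differs in just one place, so this expectation is tentative. A modest fall in the concentration needed is expected, given that compound 3 stands at 97000 nM. The expected change is a 3.2-fold lower number from compound 3 to compound 4 (0.51 log units; beyond the scatter). For compound 4 the estimated value is 30000 nM, with an expected range of 6000 nM to 100000 nM.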

Compound 4, half-maximal effective concentration: 96000 nM
Compound 4: middle estimate off by 3.2-fold (0.51 log units), on the low side; the range from low to high includes it.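

In this assay, the step of a 1.0-fold lower number from compound 3 to compound 4 (0.00 log units; within the scatter) comes with thiophen-2-yl in place of methoxymethyl on a saturated chain carbon bound to an amine nitrogen. This first readable comparison shows that an aromatic ring and an open ether chain at this place give values that cannot be told apart. No measurement shown offers an explanation for this result. Still open, on these data alone, is whether furan-2-yl, a hydroxyl group or a longer chain at this place would give a step beyond the scatter.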